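The source may report more compounds than this note shows. Statements on the series, on what has been measured and on what is new or still open speak of the compounds shown alone.

Two compounds share one core and differ only in the group attached to it. Compound 1 `CC(C(=O)NCc1ccc(C(F)(F)F)nc1-c1ccc(Cl)cc1)c1ccc(NS(C)(=O)=O)c(F)c1` carries a chlorophenyl group there, and in an assay on CHO cells for antagonist activity at transient receptor potential cation channel subfamily V member 1 (Homo sapiens), read by FLIPR (on this read-out higher numbers stand for weaker inhibition and lower numbers for stronger inhibition), compound 1 gives 0.7 nM. Compound 2 `CC(C(=O)NCc1ccc(C(F)(F)F)nc1-c1ccc(N(C)C)cc1)c1ccc(NS(C)(=O)=O)c(F)c1` carries a 4-(dimethylamino)phenyl group in the same position, and in this assay compound 2 gives 3.2 nM. Among the measured compounds shown here, the single measured step, a 4.6-fold higher number from compound 1 to compound 2 (0.66 log units; beyond the scatter), shows that swapping the group at this position can shift the number by a modest amount. Among the two numbers measured so far, compound 2 stands highest, with compound 1 the nearest at a lower value.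

Compound 3 `CC(C(=O)NCc1ccc(C(F)(F)F)nc1-c1ccco1)c1ccc(NS(C)(=O)=O)c(F)c1` is the next step from compound 2: furan-2-yl in place of 4-(dimethylamino)phenyl on an aromatic carbon. For the measured compounds named here, the aromatic group is smaller and of a different kind, so the one measured step bears on it only loosely; it suggests that changes here matter, but not in which direction this one will go. A modest step is therefore expected, with weakening slightly more likely than strengthening, as a 1.6-fold higher number from compound 2 to compound 3 (0.19 log units; within the scatter). For compound 3 in this assay the estimate is 5 nM, within a range from 1.2 nM to 20 nM.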

Compound 3, inhibition constant: 5.8 nM
Compound 3: the middle estimate sits 1.2-fold (0.06 log units) below what was measured; the measured number falls inside the stated range.
By their numbers in this assay, from the lowest: compound 1; then compounds 2 and 3 (each within the scatter of the next).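

In this assay, the step of a 1.8-fold higher number from compound 2 to compound 3 (0.26 log units; within the scatter) shows that the 4-(dimethylamino)phenyl group can give way to furan-2-yl, a five-membered ring with 5 heavy atoms instead of 9, with no change that can be told from scatter, so compounds 2 and 3 cannot be ranked against each other. The comparison with the chlorinated compound, an 8.3-fold higher number from compound 1 to compound 3 (0.92 log units; beyond the scatter), lies beyond the scatter, and compound 1 now stands apart as the strongest of the three, since its steps to the other two are both beyond the scatter. Nothing measured here explains why the 4-chlorophenyl group gives the lowest number, and no supporting data bear on this result.

The compounds shown do not separate the role of the chlorine from that of the six-membered ring, a question that a plain phenyl group or a 4-fluorophenyl group at this position would address. They also leave open whether an aromatic ring is needed here at all, which a saturated ring such as cyclohexyl or morpholine would test.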